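Solubility notes: aryl-amide series, compound 4 estimate

The compounds below may be only part of what the source reports. "The series", "measured", "known", "first", "only" and "open" are said of these compounds alone.

Measured so far:
compound 1 `Cc1cc(C)c(-c2cn(C)cn2)cc1NC(=O)c1ccc(OCc2ccccn2)cc1` 8000 nM
compound 2 `Cc1cc(F)c(-c2ncc[nH]2)cc1NC(=O)c1ccc(OCc2ccccn2)cc1` 1000 nM
compound 3 `Cc1cc(C)c(-c2c(C)nn(C)c2C)cc1NC(=O)c1ccc(OCc2ccccn2)cc1` 35000 nM

In a physicochemical assay for solubility, at pH 7.4 (on this read-out higher numbers stand for higher solubility and lower numbers for lower solubility), compound 3 stands highest of the three; its nearest neighbour is compound 1 and its furthest is compound 2. Within the data shown here, the one measured step, a 4.4-fold higher number from compound 1 to compound 3 (0.64 log units; beyond the scatter), is the only step touching this position. Compound 4 `Cc1cc(C)c(-c2cccc(N)n2)cc1NC(=O)c1ccc(OCc2ccccn2)cc1` has not been measured; it differs from compound 3 by 6-aminopyridin-2-yl in place of 1,3,5-trimethyl-1H-pyrazol-4-yl on an aromatic carbon. Among the measured compounds shown here, no measured step covers this exchange; the step from compound 1 to compound 3 shows that changing the group at this position moves the number by a modest amount, and compound 2 shows a lower value with a group carrying a hydrogen-bond donor. Compound 4 is therefore expected to sit below compound 3, a 4.4-fold lower number from compound 3 to compound 4 (0.64 log units; beyond the scatter), with an estimate of 8000 nM and a range of 2000 nM to 30000 nM.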

Compound 4, solubility: 2000 nM
Compound 4: the middle estimate sits 4.0-fold (0.60 log units) above what was measured; measured number inside the range.
By their numbers in this assay, from the lowest: compounds 2 and 4 (each within the scatter of the next); then compound 1; then compound 3.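

In this assay 6-aminopyridin-2-yl gives an 18-fold lower number from compound 3 to compound 4 (1.24 log units; beyond the scatter) and also a 4.0-fold lower number from compound 1 to compound 4 (0.60 log units; beyond the scatter) on the same core, so this position reaches lower numbers than the two earlier groups there showed. Compounds 1, 3 and 4 now separate beyond the scatter, with compound 4 lowest of these three. No measurement at hand bears on the cause of these steps.

Open is whether the steps follow the amine or the six-membered ring, as neither pyridin-2-yl without the amine nor a methylamino group on that ring stands among the compounds shown.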